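The compounds below may be only part of what the source reports. "The series", "measured", "known", "first", "only" and "open" are said of these compounds alone.

In a functional assay on HCT-116 cells (Homo sapiens) for antiproliferative activity, read by MTT assay, with a stated time of 72 h (on this read-out lower numbers stand for stronger inhibition and higher numbers for weaker inhibition), compound 1 (`O=C(NCc1ccccc1)c1csc(NC(=S)Nc2ccc(Cl)cc2)n1`) reads 62200 nM and compound 2 (`Cc1ccc(-c2c(CN3CCCCC3)nc3scc(C(=O)O)n23)cc1`) reads 13800 nM as the lower of the two numbers, a gap beyond the scatter. These two compounds are not linked by a change in one place, so the series offers no measured single change to lean on. Compound 3 (`COc1ccc(-c2c(CN3CCCCC3)nc3scc(C(=O)O)n23)cc1`) keeps the shared core of compound 2 and alters one group: methoxy in place of methyl on an aromatic carbon as methoxy in place of methyl on an aromatic carbon, that is 4-methylphenyl to 4-methoxyphenyl. Starting from compound 2 at 13800 nM as the only anchor, no shift beyond the scatter is expected in this assay in either direction. The estimated 1.2-fold lower number from compound 2 to compound 3 (0.06 log units; within the scatter) stays small on that view. Compound 3 is estimated at 12000 nM within an expected range from 5500 nM to 30000 nM on this read-out.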

Compound 3, half-maximal inhibitory concentration: 84600 nM
For compound 3 the middle estimate is 7.1-fold (0.85 log units) below the measured one; the measured number lies above the stated range.
By their numbers in this assay, from the lowest: compound 2; then compounds 1 and 3 (each within the scatter of the next).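

In this assay, the series now has its first measured single change: methoxy in place of methyl on an aromatic carbon, para to a large group, gives a 6.1-fold higher number from compound 2 to compound 3 (0.79 log units; beyond the scatter). This position is therefore not indifferent to its group, since 4-methylphenyl and 4-methoxyphenyl on the otherwise shared core separate beyond the scatter, which the earlier unlinked compounds could not show. No measured evidence here bears on why this change raises the number.

With one step at this position, the compounds shown cannot establish whether the outcome follows a wider pattern among its groups. As far as these compounds go, an amine, a hydroxyl group or a longer chain on the same aromatic carbon remains open, as does whether the step holds with another group in place of the carboxylic acid.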